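Compound 3 to Compound 4: One Double Bond, Two Geometries

This account rests on a few compounds, and the source may have more. Where it says the series, first, only, none or still open, it means among the compounds named here.

Measured in an ADME assay on a cell-free system (plasma, Homo sapiens) for metabolic stability, read by LC-MS, with a stated time of 60 min, at 37 degrees C, tested at 50 uM; a higher number here means that more of the compound is left, a lower number that less of the compound is left:
compound 1 `CCCCOC(=O)C1=C(S[C@@H]2CN[C@H](C(=O)Nc3cccc(C(=O)OCCCC)c3)C2)[C@H](C)[C@@H]2[C@@H]([C@@H](C)O)C(=O)N12` gives 1%
compound 2 `C[C@@H](O)[C@H]1C(=O)N2C(C(=O)OCOC(=O)C(C)(C)C)=C(S[C@@H]3CN[C@H](C(=O)Nc4cccc(C(=O)O)c4)C3)[C@H](C)[C@H]12` gives 45%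
compound 3 `Cc1oc(=O)oc1COC(=O)N1C[C@@H]2C[C@H]1C(=O)Nc1cccc(c1)C(=O)OC/C=C/COC(=O)C1=C(S2)[C@H](C)[C@@H]2[C@@H]([C@@H](C)O)C(=O)N12` gives 17%

On these three numbers compound 3 stands second highest in this assay. Its nearest neighbour is compound 1, whose value lies lower by a gap beyond the usual scatter of repeated runs; the most distant is compound 2, whose value lies higher, again by a gap beyond the scatter. Compound 3 therefore sits between the two, closer to the lower of them.

Compound 4 `Cc1oc(=O)oc1COC(=O)N1C[C@@H]2C[C@H]1C(=O)Nc1cccc(c1)C(=O)OC/C=C\COC(=O)C1=C(S2)[C@H](C)[C@@H]2[C@@H]([C@@H](C)O)C(=O)N12` has not yet been measured in this assay. Set beside compound 3, (the two compounds have the same atoms and bonds and differ only in configuration as drawn: 1 of 7 stereo elements differ; a double bond is drawn E in compound 3 and Z in compound 4). For the measured compounds named here, nothing leaves and nothing enters; the same atoms and bonds are present in both, and the only change drawn is the geometry of one double bond, E in compound 3 and Z in compound 4.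

Going by the values given here, no measured pair in this set differs by such a change alone, so there is no step on record to lean on. With no atom added or removed, the expected step is no change at the digits printed from compound 3 to compound 4 (within the scatter), that is, none beyond the scatter in either direction. Compound 4 is accordingly estimated at 17% in this assay, with a range from 5% to 35% to allow for the absence of any precedent for this kind of change.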

Compound 4, percent of the compound remaining: 20%
Compound 4: middle estimate off by 3 percentage points, on the low side; the range from low to high includes it.
By their numbers in this assay, from the lowest: compound 1; then compounds 3 and 4 (each within the scatter of the next); then compound 2.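

The three earlier compounds offered no pair differing in one place, and this pair is the first to do so, with a single change of drawn configuration: the fact that compounds 3 and 4 differ only in the configuration as drawn

In this assay, the step reads a number 3 percentage points higher from compound 3 to compound 4 (within the scatter), so the E and Z forms of this double bond cannot be told apart by the percentage of compound remaining. This gives the set its first measured reference for a change of geometry at this position, although that reference rests on this one pair alone.

The compounds shown leave open whether any change to this chain other than its geometry would separate the values in this assay, such as replacing the double bond with a saturated carbon-carbon bond or a triple bond, or using a longer chain. They also leave open whether the same change of geometry would read alike with a free amine in place of the carbamate on the ring nitrogen, since compound 3 and compound 4 both carry that carbamate.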